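The source may hold more compounds than are shown below. What is called first, only, known or untested is meant among the compounds shown, and "the series" means these compounds.

Compound 1 `C[Si](C)(C)CCOCn1nnc2c(C(N)=O)ncn2c1=O`: 25300 nM
Compound 2 `NC(=O)c1ncn2c(=O)n(Cc3ccco3)nnc12`: > 50000 nM

Both compounds were tested in a functional assay on U-373MG ATCC cells for inhibition, with U373 MG (Homo sapiens) as the target, read by MTT assay, with a stated time of 7 days; on this read-out higher numbers stand for weaker inhibition of growth and lower numbers for stronger inhibition of growth. As far as these compounds go, for compound 2 there is only a limit of the assay, > 50000 nM, and not a number, so its exact place on the scale is unknown. This is the limit of > 50000 nM in this assay, at which 1 of the 2 values shown sits.

The next compound, compound 3 `NC(=O)c1ncn2c(=O)n(Cc3cccs3)nnc12`, has not yet been measured. It carries thiophen-2-yl in place of furan-2-yl on a saturated chain carbon bound to an aromatic nitrogen. The ring size stays the same, and only the hetero atom differs.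

Just one measured step bears on this change, and it exchanges a different pair of groups at the same place: an at least 1.9-fold higher number from compound 1 to compound 2 (0.29 log units; that floor lies within the scatter). From the compounds shown here alone, its true size is unknown, and it gives no sign of a large move in either direction. No step beyond the scatter is therefore expected in this assay, and the result may again be only a limit. The expected change is a number no higher from compound 2 to compound 3 (the limit leaves the size open). Compound 3 is estimated at 50000 nM, with an expected range from 25000 nM to 100000 nM.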

Compound 3, concentration for 50% growth inhibition: > 50000 nM
Compound 3 ended at the assay's limit (the forecaster's own chance of this, stated with the estimate: 60%); the middle value lies on the limit itself.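

In this assay compound 3 gives > 50000 nM, which is a limit of the assay and not a number. Among the compounds shown here, the one step that can be read is an at least 1.9-fold higher number from compound 1 to compound 3 (0.29 log units; that floor lies within the scatter), so the second five-membered aromatic ring at this place, like the first, shows no move beyond the scatter from the silicon-bearing group, although the true size of the step is unknown. The step from furan-2-yl to thiophen-2-yl cannot be read, because both compounds stop at the same limit, and exchanging oxygen for sulfur in the ring therefore gives no measurable comparison: the limit of > 50000 nM in this assay, at which 2 of the 3 values shown sit.

As far as these compounds go, how far compound 2 and compound 3 lie past this limit stays open, and so does whether the two rings differ at all in this assay. Also open, from the compounds shown here alone, is whether another group on the saturated chain carbon bound to an aromatic nitrogen, such as a phenyl ring or a longer chain ending in an amine, would give a real number, and how that number would compare with compound 1, which gives 25300 nM.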